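The compounds below may be only part of what the source reports. "The series", "measured", "known", "first", "only" and "open" are said of these compounds alone.

Measured so far in a functional assay on A549 cells (Homo sapiens) for cytotoxicity, read by MTT assay, with a stated time of 4 days; a lower number here means a stronger inhibitor, a higher number a weaker inhibitor:
compound 1 `Cc1ccc(S(=O)(=O)Oc2ccc3c(c2C)[C@H](Cn2cc(-c4ccccc4)nn2)[C@@]24CC(=O)[C@@](C)(CC[C@@H]32)C4)cc1` gives > 20000 nM, a limit of the assay.
compound 2 `C=C1C(=O)[C@]23C[C@@]1(O)CC[C@H]2c1ccc(OS(=O)(=O)c2ccc(C)cc2)c(C)c1[C@@H]3Cn1cc(-c2ccc(Cl)cc2)nn1` gives 1870 nM.
compound 3 `C=C1C[C@]23C[C@@]1(O)CC[C@H]2c1ccc(OS(=O)(=O)c2ccc(C)cc2)c(C)c1[C@@H]3Cn1cc(-c2ccc(OC)cc2)nn1` gives > 20000 nM, a limit of the assay.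

Compound 1 stands at the limit of this assay; no number is known for it, only that it lies beyond the tested range. Compound 3 sits at the same limit. Compound 2 alone returns a number, and it differs from compound 1 in the core as well as in the group on the phenyl ring, so the two values cannot be read as a single step.

Compound 4 `Cc1ccc(S(=O)(=O)Oc2ccc3c(c2C)[C@H](Cn2cc(-c4ccc(F)cc4)nn2)[C@@]24CC(=O)[C@@](C)(CC[C@@H]32)C4)cc1` is next to be measured. It differs from compound 1 in one place: fluoro in place of hydrogen on an aromatic carbon. Going by the values given here, no pair of measured compounds differs only in this way, so the size of such a step is not known from the series. Two of the three values shown sit at the limit (the limit of > 20000 nM in this assay, at which 2 of the 3 values shown sit), and the core shared by compound 1 and compound 4 is the one that returned the limit. The expected step of a number no higher from compound 1 to compound 4 (the limit leaves the size open) is therefore small, not beyond the usual scatter. The estimate for compound 4 is 20000 nM, with a range from 6000 nM to 60000 nM, and most likely this assay again reports only a limit.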

Compound 4, half-maximal inhibitory concentration: > 20000 nM
Compound 4: no number, only a limit; the forecaster's own chance of this, stated with the estimate: 65%; the middle value lies on the limit itself.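

Compound 1 and compound 4 each return only a limit in this assay, so the change from phenyl to 4-fluorophenyl gives no readable step between them: the limit of > 20000 nM in this assay, at which 3 of the 4 values shown sit.

The compounds shown leave open what size of step, if any, fluoro in place of hydrogen on an aromatic carbon gives on the core shared by compound 1 and compound 4.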